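The source may report more compounds than this note shows. Statements on the series, on what has been measured and on what is new or still open speak of the compounds shown alone.

Within the data shown here, compound 1 `Cc1ccc(C(=O)Nc2cc(-c3ccccc3)nn2-c2ccccc2)cc1` gives 40 nM in an assay on isolated protein with metabotropic glutamate receptor 5 (Rattus norvegicus) as the target (on this read-out lower numbers stand for an effect already at smaller amounts and higher numbers for an effect only at larger amounts of compound), the lowest of the three numbers so far. Compound 3 `Cc1cccc(C(=O)Nc2cc(-c3ccccc3)nn2-c2ccccc2)c1` gives 100 nM, and compound 2 `O=C(Nc1cc(-c2ccccc2)nn1-c1ccccc1)c1ccccn1` gives 585 nM. Compound 4 `O=C(Nc1cc(-c2ccccc2)nn1-c1ccccc1)c1ccsc1` differs from compound 1 by thiophen-3-yl in place of 4-methylphenyl on a carbonyl carbon. Two measured steps from compound 1 bear on this: the exchange for 3-methylphenyl, a 2.5-fold higher number from compound 1 to compound 3 (0.40 log units; beyond the scatter), and the exchange for pyridin-2-yl, a 15-fold higher number from compound 1 to compound 2 (1.17 log units; beyond the scatter). Both raise the number, the second more. Since compound 4 carries a five-membered aromatic ring with 1 hetero atom on the carbonyl carbon, a rise in this assay beyond the scatter is expected, probably between those two steps, i.e. a 4.0-fold higher number from compound 1 to compound 4 (0.60 log units; beyond the scatter). Compound 4 is thus estimated at 160 nM, within 50 nM to 600 nM.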

Compound 4, half-maximal effective concentration: 2900 nM
Beside the measured number, compound 4's estimate is 18-fold (1.26 log units) below it, outside the stated range (above it).
By their numbers in this assay, from the lowest: compound 1; then compound 3; then compound 2; then compound 4.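

Thiophen-3-yl on the carbonyl carbon gives the highest number so far in this assay, well above both methylphenyl compounds (a 73-fold higher number from compound 1 to compound 4 (1.86 log units; beyond the scatter)) (a 29-fold higher number from compound 3 to compound 4 (1.46 log units; beyond the scatter)) and even above the pyridin-2-yl compound (a 5.0-fold higher number from compound 2 to compound 4 (0.70 log units; beyond the scatter)). Among these compounds, both rings carrying a hetero atom now stand above both methylphenyl rings, with no compound against that order, and the five-membered ring is the further off. No measurement shown explains this rise.

Open, as far as these compounds go, is whether ring size, the sulfur or the lost methyl governs the change. Plain phenyl or methylthiophen-3-yl on this carbonyl carbon would separate these.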